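Replacing cyclopentyl on the aromatic nitrogen: working notes

This account rests on a few compounds, and the source may have more. Where it says the series, first, only, none or still open, it means among the compounds named here.

Measured in an ADME assay on microsomes from liver (Homo sapiens) for metabolic stability, read by LC-MS, using NADPH, with a stated time of 10 min, tested at 10 uM; on this read-out lower numbers stand for a shorter-lived compound and higher numbers for a longer-lived compound:
- compound 1 `Nc1ncnc2c1c(Oc1cc(C(F)(F)F)ccn1)nn2C1CCCC1`: 0.333 h
- compound 2 `Nc1ncnc2c1c(Oc1cc(C(F)(F)F)ccn1)nn2CC1CC1`: 1.87 h
- compound 3 `Nc1ncnc2c1c(Oc1cc(C(F)(F)F)ccn1)nn2[C@H]1CC[C@H](CO)CC1`: > 2.41 h, a limit of the assay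

The lowest number in the series belongs to compound 1. Replacing its cyclopentyl gave a 5.6-fold higher number from compound 1 to compound 2 (0.75 log units; beyond the scatter) and an at least 7.2-fold higher number from compound 1 to compound 3 (0.85 log units; beyond the scatter), both beyond the scatter.

Compound 4 `Nc1ncnc2c1c(Oc1cc(C(F)(F)F)ccn1)nn2[C@H]1C[C@H](F)C1` carries a new change: 3-fluorocyclobutyl in place of cyclopentyl on an aromatic nitrogen. Only those two steps bear on it, so a rise beyond the scatter is expected in this assay, landing near compound 2 at 1.87 h. The estimated step is a 4.5-fold higher number from compound 1 to compound 4 (0.65 log units; beyond the scatter). For compound 4 the expected half-life is 1.5 h, with an estimated range of 0.6 h to 3.5 h.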

Compound 4, half-life: 2.03 h
Beside the measured number, compound 4's estimate is 1.4-fold (0.13 log units) below it; measured number inside the range.
By their numbers in this assay, from the lowest: compound 1; then compounds 2 and 4 (each within the scatter of the next). At a limit, above all of these: compound 3.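

In this assay, a four-membered ring carrying fluorine on the aromatic nitrogen also moves the number away from that of cyclopentyl, with a 6.1-fold higher number from compound 1 to compound 4 (0.79 log units; beyond the scatter). Against cyclopropylmethyl, 3-fluorocyclobutyl gives a 1.1-fold higher number from compound 2 to compound 4 (0.04 log units; within the scatter). Against 4-(hydroxymethyl)cyclohexyl, 3-fluorocyclobutyl gives an at least 1.1-fold lower number from compound 3 to compound 4 (0.07 log units; that floor lies within the scatter). Compound 3 stands at a limit of the assay: the limit of > 2.41 h in this assay, at which 1 of the 4 values shown sits.

Going by these compounds, how a plain cyclobutyl without fluorine, or a cyclobutyl carrying an amine, would behave at this position remains open.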